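Swapping Naphthalene for Fluorophenyl on Two Related Cores

The compounds below may be only part of what the source reports. "The series", "measured", "known", "first", "only" and "open" are said of these compounds alone.

Compound 1 `O=C1N/C(=N/c2csc(-c3ccc(Cl)cc3)c2)S/C1=C\c1ccc2ccccc2c1` and compound 3 `O=C1N/C(=N/c2nc(-c3ccc(Cl)cc3)cs2)S/C1=C\c1ccc2ccccc2c1` resemble each other closely but differ in the ring that links their two parts; how the two cores differ is not broken down here. In a functional assay on MCF7 cells (Homo sapiens) for cytotoxicity, read by MTT assay, with a stated time of 72 h (a lower number here means a stronger inhibitor, a higher number a weaker inhibitor), compound 1 gives 1200 nM, and compound 3 gives 300 nM. Compound 2 `O=C1N/C(=N/c2csc(-c3ccc(Cl)cc3)c2)S/C1=C\c1ccc(F)cc1` differs from compound 1 by one change: 4-fluorophenyl in place of naphthalen-2-yl on a double-bonded chain carbon bound to a double-bonded ring carbon. For compound 2 the result in this assay is a limit of the assay, > 50000 nM (the limit of > 50000 nM in this assay, at which 1 of the 3 values shown sits). The step of an at least 41-fold higher number from compound 1 to compound 2 (1.61 log units; beyond the scatter) is thus known only as a floor. Compound 4 `O=C1N/C(=N/c2nc(-c3ccc(Cl)cc3)cs2)S/C1=C\c1ccc(F)cc1` carries the same change on the core of compound 3: 4-fluorophenyl in place of naphthalen-2-yl on a double-bonded chain carbon bound to a double-bonded ring carbon. An expected step of a 100-fold higher number from compound 3 to compound 4 (2.00 log units; beyond the scatter) rests on the measured step of an at least 41-fold higher number from compound 1 to compound 2 (1.61 log units; beyond the scatter). Compound 4 is therefore expected near 30000 nM, probably between 8000 nM and 100000 nM, with a real chance that only a limit is reported.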

Compound 4, half-maximal inhibitory concentration: > 50000 nM
Compound 4: only a limit was reported (the forecaster's own chance of this, stated with the estimate: 50%); at least 1.6-fold (0.22 log units) between middle value and limit.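

Compound 4 gives > 50000 nM in this assay and this is a limit of the assay. Placing 4-fluorophenyl in place of naphthalen-2-yl gives an at least 160-fold higher number from compound 3 to compound 4 (2.22 log units; beyond the scatter) and so the large weakening seen on the core of compound 1 also appears on the core of compound 3, at least for these two cores. Whether the loss is the same size on both cores is not shown: the same change on two cores in this assay, an at least 41-fold higher number (1.61 log units; beyond the scatter) from compound 1 to compound 2 and an at least 160-fold higher number (2.22 log units; beyond the scatter) from compound 3 to compound 4; the limit leaves it open whether they differ

Going by these compounds, only these two groups appear at this place, so it remains open how a plain phenyl, a methoxyphenyl or a group carrying an amine would behave on either core. Also open, on these data alone, is how weak compound 2 and compound 4 really are.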